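The source may hold more compounds than are shown below. What is called first, only, known or untested is meant among the compounds shown, and "the series" means these compounds.

Compound 2 `COc1ccc(Sc2nc3cc(N)cc(N)c3nc2-c2ccccc2)cc1` is known in a functional assay on NCI-H460 cells (Homo sapiens) for inhibition, read by sulforhodamine B assay, with a stated time of 48 h (on this read-out lower numbers stand for higher toxicity in this test and higher numbers for lower toxicity in this test), only as a limit, < 100000 nM, which is not a number. The related compound 1 `Nc1cc(N)c2nc(-c3ccccc3)c(Oc3ccc(Cl)c(Cl)c3)nc2c1` likewise gives in this assay only the limit < 100000 nM. The change to compound 3 `Nc1cc(N)c2nc(-c3ccccc3)c(Sc3ccc(Cl)c(Cl)c3)nc2c1` is 3,4-dichlorophenyl in place of 4-methoxyphenyl on a sulfur. Within the data shown here, the one measured step that bears on it, a step that the two limits leave unreadable from compound 1 to compound 2, cannot be read, since (the limit of < 100000 nM in this assay, at which 2 of the 2 values shown sit). No readable step therefore guides the expectation, and compound 3 is expected to stay near the same limit, a step that the limit leaves unreadable from compound 2 to compound 3 being estimated. The value of compound 3 is estimated at 60000 nM, within 10000 nM to 150000 nM.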

Compound 3, concentration lethal to 50% of the cells: < 100000 nM
Compound 3 gave a limit, no number; the forecaster's own chance of this, stated with the estimate: 65%; the middle value is on the limit's open side.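

No step among compound 1, compound 2 and compound 3 can be read in this assay, since each gives only a limit, not a number: the limit of < 100000 nM in this assay, at which 3 of the 3 values shown sit.

Going by these compounds, whether 3,4-dichlorophenyl and 4-methoxyphenyl on a sulfur differ in this assay stays open.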